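Thiophen-2-yl in place of phenyl in compound 1

A few compounds are considered here, and "the series" means these few. Any claim that something is new, unique, unknown or untested is made for them only; others in the source may bear on it.

compound 1 `O=C1Nc2c(ccc(F)c2F)C1(c1ccccc1)c1ccc(O)cc1` gives 7.1 nM
compound 2 `CCCOc1ccc(C2(c3ccc(O)cc3)C(=O)Nc3c2ccc(F)c3F)cc1` gives 356 nM
compound 3 `COc1ccc(C2(c3cccc(O)c3)C(=O)Nc3c2ccc(F)c3F)cc1` gives 196 nM

All three values come from a functional assay on MCF7 cells (Homo sapiens) for cytotoxicity, read by WST assay, with a stated time of 72 h (on this read-out higher numbers stand for weaker inhibition and lower numbers for stronger inhibition), and compound 1 has the lowest number, with both other compounds beyond the scatter from it. Still unmeasured is compound 4 `O=C1Nc2c(ccc(F)c2F)C1(c1ccc(O)cc1)c1cccs1` which differs from compound 1 by one exchange. The change is thiophen-2-yl in place of phenyl on a saturated ring carbon so thiophen-2-yl stands in place of phenyl on a saturated ring carbon.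

Going by the values given here, the only measured single change is a 50-fold higher number from compound 1 to compound 2 (1.70 log units; beyond the scatter) for propoxy in place of hydrogen on an aromatic carbon. That large step comes from adding a group, whereas compound 4 exchanges one aromatic ring for another, so it bears only loosely on this swap. Among the compounds with values here, compound 3 differs from compound 1 in more than one place and offers no clean step. With nothing measured on this exchange, no clear shift is expected in this assay and the expected outcome is a 1.4-fold higher number from compound 1 to compound 4 (0.15 log units; within the scatter) without any firm direction. The estimated value for compound 4 is 10 nM with an expected range of 3 nM to 40 nM around it.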

Compound 4, half-maximal inhibitory concentration: 82 nM
Beside the measured number, compound 4's estimate is 8.2-fold (0.91 log units) below it, and the stated range ends below it.
By their numbers in this assay, from the lowest: compound 1; then compound 4; then compounds 3 and 2 (each within the scatter of the next).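

In this assay, thiophen-2-yl in place of phenyl on the saturated ring carbon gives a 12-fold higher number from compound 1 to compound 4 (1.06 log units; beyond the scatter). Going by these compounds alone, the earlier single step concerned an aromatic carbon, so this is the first clean reading at the saturated ring carbon, and it shows that the value responds strongly even when one aromatic ring is exchanged for another, here a six-membered ring of carbon only for a five-membered ring with sulfur. Nothing measured among these compounds gives a reason for this step.

Still open, as far as these compounds go, is how other groups at this carbon would compare, such as furan-2-yl, thiophen-3-yl, pyridin-3-yl or the non-aromatic cyclohexyl. From the compounds shown here alone, it is also open whether the exchange would give a step of similar size in a compound carrying the propoxy group.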